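Trans to cis: turning the double bond of compound 1

The compounds below may be only part of what the source reports. "The series", "measured", "known", "first", "only" and "open" are said of these compounds alone.

Measured compounds:
- compound 1, `COc1cc(/C=C/c2ccc(C(C)C)cc2)cc(OC)c1OC`: 11.1 uM
- compound 2, `CCOc1ccc(/C=C/c2cc(OC)c(OC)c(OC)c2)cc1`: 1.17 uM

In a functional assay on SK-MEL-5 cells (Homo sapiens) for cytotoxicity (a higher number here means that more compound is needed for the effect, a lower number that less compound is needed), compound 1 gives the higher of the two numbers; its nearest neighbour is compound 2, reached by a 9.5-fold lower number from compound 1 to compound 2 (0.98 log units; beyond the scatter). Compound 3, `COc1cc(/C=C\c2ccc(C(C)C)cc2)cc(OC)c1OC`, is not yet measured. Compared with compound 1, (the two compounds have the same atoms and bonds and differ only in configuration as drawn: 1 of 1 stereo elements differ; a double bond is drawn E in compound 1 and Z in compound 3). Going by the values given here, the only measured step, the exchange of an isopropyl for an ethoxy, concerns a different kind of change and says nothing about a flip of the double bond, so no measured step bears on the change from compound 1 to compound 3. The direction and size of the step in this assay therefore cannot be read from the data shown, and the expectation is correspondingly wide. Compound 3 is expected to give about 1 uM, within a range of 0.05 uM to 15 uM. This estimate corresponds to an expected step of an 11-fold lower number from compound 1 to compound 3 (1.05 log units; beyond the scatter).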

Compound 3, concentration for half-maximal effect: 4.7 uM
Beside the measured number, compound 3's estimate is 4.7-fold (0.67 log units) below it, and the stated range covers the measured number.
By their numbers in this assay, from the lowest: compound 2; then compound 3; then compound 1.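

In this assay, the geometry of the double bond matters in its own right, with the flip from E to Z giving a 2.4-fold lower number from compound 1 to compound 3 (0.37 log units; beyond the scatter). Going by these compounds alone, the earlier pair showed only that the number responds to a change of the group on the aromatic ring, whereas here that group stays isopropyl and the number still moves. This step can be assigned to the double bond alone, because nothing else in the structure changes: the fact that compounds 1 and 3 differ only in the configuration as drawn.

The compounds shown leave open whether the same flip would lower the number to a similar extent with ethoxy in place of isopropyl, or with a different group there, such as an amine or a longer chain. They also do not show what happens inside the cells to produce the difference between the E and Z forms.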